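The compounds below may be only part of what the source reports. "The series", "measured", "known", "first", "only" and "open" are said of these compounds alone.

Measured in an ADME assay on microsomes from liver (Homo sapiens) for metabolic stability, read by LC-MS, using NADPH, with a stated time of 30 min, tested at 1 uM; on this read-out higher numbers stand for fast clearance and lower numbers for slow clearance:
- Compound 1 (`CC(C)c1noc(N2CCC(Oc3cc(N4CCc5cc(C6CCCCC6=O)ccc54)ncn3)CC2)n1`) gives 78 mL.min-1.g-1
- Compound 2 (`CC(C)c1noc(N2CCC(Oc3cc(N4CCc5cc(N6CCCNS6(=O)=O)ccc54)ncn3)CC2)n1`) gives 79 mL.min-1.g-1
- Compound 3 (`CC(C)c1noc(N2CCC(Oc3cc(N4CCc5cc(N6CC(O)CCC6=O)ccc54)ncn3)CC2)n1`) gives 1 mL.min-1.g-1

Compound 3 holds the lowest number of the three. The measurements show a 78-fold lower number from compound 1 to compound 3 (1.89 log units; beyond the scatter) and a 79-fold lower number from compound 2 to compound 3 (1.90 log units; beyond the scatter), two large steps, while the remaining pair shows a 1.0-fold higher number from compound 1 to compound 2 (0.01 log units; within the scatter). Compound 4 (`CC(C)c1noc(N2CCC(Oc3cc(N4CCc5cc(N6CCCS6(=O)=O)ccc54)ncn3)CC2)n1`) has not yet been measured. It departs from compound 3 in one place, on an aromatic carbon of a six-membered aromatic ring of carbon only (a group of 7 heavy atoms (3 carbon, 1 nitrogen, 2 oxygen, 1 sulfur; one five-membered non-aromatic ring with 2 hetero atoms) in place of a group of 8 heavy atoms (5 carbon, 1 nitrogen, 2 oxygen; one six-membered non-aromatic ring with 1 hetero atom), on an aromatic carbon).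

Of the three measured compounds, only compound 3 carries the 5-hydroxy-2-oxopiperidin-1-yl group, and compound 4 loses it. The closest guide is compound 2, which also has a sulfur-containing ring at this place and sits high, with a 79-fold lower number from compound 2 to compound 3 (1.90 log units; beyond the scatter) as its measured step. Compound 1 points the same way through a 78-fold lower number from compound 1 to compound 3 (1.89 log units; beyond the scatter). Within the data shown here, no measured compound carries the five-membered ring of compound 4, and three compounds are a thin basis, so a somewhat smaller step than these is allowed for. The expected change is a large rise in the number, estimated as a 50-fold higher number from compound 3 to compound 4 (1.70 log units; beyond the scatter). For compound 4 the estimated value is 50 mL.min-1.g-1, with an expected range from 15 mL.min-1.g-1 to 130 mL.min-1.g-1.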

Compound 4, intrinsic clearance in microsomes: 18 mL.min-1.g-1
The estimate for compound 4 lay 2.8-fold (0.44 log units) above the measured number; the range from low to high includes it.
By their numbers in this assay, from the lowest: compound 3; then compound 4; then compounds 1 and 2 (each within the scatter of the next).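

In this assay, the five-membered sulfur-containing ring of compound 4 places this position at an intermediate level: the change is an 18-fold higher number from compound 3 to compound 4 (1.26 log units; beyond the scatter), yet there is also a 4.4-fold lower number from compound 2 to compound 4 (0.64 log units; beyond the scatter) and a 4.3-fold lower number from compound 1 to compound 4 (0.64 log units; beyond the scatter). The position therefore does not divide simply into the 5-hydroxy-2-oxopiperidin-1-yl group with a low number and all other groups with a high one, since a group without it can still lie clearly below the two highest compounds. Compound 2 and compound 4 both carry a sulfur-containing ring here and still differ beyond the scatter, so the presence of sulfur in the ring does not alone set the clearance number, and nothing available explains any of these differences.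

It remains open which part of the 5-hydroxy-2-oxopiperidin-1-yl group goes with the low number of compound 3, as the plain 2-oxopiperidin-1-yl ring without its hydroxyl is not among the compounds shown. As far as these compounds go, it is also open how the number would respond to an open-chain group at this aromatic carbon, such as a simple amine or a carboxylic acid.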